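Swapping a pyridine for a thiophene on a shared core

A few compounds are considered here, and "the series" means these few. Any claim that something is new, unique, unknown or untested is made for them only; others in the source may bear on it.

Compound 1 `CC(C)(C)Cc1c(-c2cccnc2)sc(N)c1C(=O)c1ccc(Cl)cc1` was tested in an assay on CHO cells for displacement of a labelled ligand from adenosine receptor A1 (Homo sapiens), read by scintillation counting, tested at 10 uM (a lower number here means less inhibition, a higher number more inhibition at the concentration tested (going by the name of the read-out)), where compound 1 gives 1%. Compound 2 `Cc1ccc(C(=O)c2c(N)sc(Br)c2CC(C)(C)C)cc1` gives 1% in this assay, and compound 3 `Cc1ccc(C(=O)c2c(N)sc(-c3ccccc3)c2CC(C)(C)C)cc1` gives 1%. These three values lie within the scatter of one another, so compound 1 stands level with both of its neighbours. Within the data shown here, the only measured step, no change at the digits printed from compound 2 to compound 3 (within the scatter), shows that exchanging one group on the shared core for an aromatic ring left the read-out flat.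

Compound 4 `CC(C)(C)Cc1c(-c2cccs2)sc(N)c1C(=O)c1ccc(Cl)cc1` differs from compound 1 by thiophen-2-yl in place of pyridin-3-yl on an aromatic carbon. Among the measured compounds shown here, no measured step covers this exact exchange; the flat step between compound 2 and compound 3 is the nearest guide. Compound 4 is therefore expected to give 2%, within -8% to 12%. The estimated step of a number 1 percentage points higher from compound 1 to compound 4 (within the scatter) is expected to be none beyond the scatter.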

Compound 4, a percentage reported as inhibition, at one concentration (the size of the read-out at that concentration, not a potency): 1%
For compound 4 the middle estimate is 1 percentage points above the measured one; low and high end bracket the measured number.
By their numbers in this assay, from the lowest: compounds 1, 2, 3 and 4 (each within the scatter of the next).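

In this assay, thiophen-2-yl in place of pyridin-3-yl gives no change at the digits printed from compound 1 to compound 4 (within the scatter) on the aromatic carbon next to the ring sulfur. This position therefore accepts either aromatic ring without any separation between them, and neither ring brings measurable inhibition at the concentration tested. Nothing available explains this flat result.

Going by these compounds, whether an amine or a carboxylic acid at this position would raise the inhibition stays open. So does the effect of a longer chain in place of the neopentyl group.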